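A few compounds are considered here, and "the series" means these few. Any claim that something is new, unique, unknown or untested is made for them only; others in the source may bear on it.

In an ADME assay on L02 cells (Homo sapiens) for cytotoxicity, read by MTT assay, with a stated time of 72 h (a lower number here means a stronger inhibitor, a higher number a weaker inhibitor), compound 1 `C=CC(=O)Nc1cccc(Oc2nc(Nc3ccc(OC)cc3)nc3c2CSCC3)c1` gives > 50000 nM, which is a limit of the assay and not a number. Compound 2 `CCC/C=C/C(=O)Nc1cccc(Oc2nc(Nc3ccc(OC)cc3)nc3c2CSCC3)c1` gives > 50000 nM, again a limit. From the compounds shown here alone, compound 3 `COc1ccc(Nc2nc3c(c(Oc4cccc(NC(=O)/C=C/C(C)C)c4)n2)CSCC3)cc1` gives > 50000 nM, also only a limit, so its true position is unknown. Compound 4 `COc1ccc(Nc2nc3c(c(Oc4cccc(NC(=O)/C=C/C(C)C)c4)n2)CSCC3)cn1` carries 6-methoxypyridin-3-yl in place of 4-methoxyphenyl on a nitrogen on an aromatic ring. The measured steps all concern the chain on the carbonyl, and none has a readable size: a step that the two limits leave unreadable from compound 1 to compound 2, a step that the two limits leave unreadable from compound 1 to compound 3 and a step that the two limits leave unreadable from compound 2 to compound 3. In this assay, no move beyond the scatter is expected for compound 4 because of the limit of > 50000 nM in this assay, at which 3 of the 3 values shown sit. The expected change is a step that the limit leaves unreadable from compound 3 to compound 4. Compound 4 is estimated at 60000 nM, within an expected range from 25000 nM to 150000 nM.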

Compound 4, half-maximal inhibitory concentration: > 50000 nM
Compound 4: only a limit was reported (the forecaster's own chance of this, stated with the estimate: 75%); the middle value does not contradict the limit.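

Compound 3 and compound 4 both give only a limit of the assay, so no step between them can be read: the limit of > 50000 nM in this assay, at which 4 of the 4 values shown sit.

From the compounds shown here alone, the true strength of all four compounds in this assay stays open, and so does any effect of 6-methoxypyridin-3-yl in place of 4-methoxyphenyl.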